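Working notes: from compound 3 to compound 4

This account rests on a few compounds, and the source may have more. Where it says the series, first, only, none or still open, it means among the compounds named here.

- compound 1 `COc1ccc(Cn2c(C(=O)N3CCCC3)cc3sccc32)cc1`: > 100000 nM (a limit)
- compound 2 `CCOC(=O)C1CCN(C(=O)c2cc3sccc3n2Cc2ccc(OC)cc2)CC1`: 39000 nM
- compound 3 `COc1ccc(Cn2c(C(=O)N3CCC(C(=O)NCc4cccc(Br)c4)CC3)cc3sccc32)cc1`: > 100000 nM (a limit)

In an ADME assay on HEK-293T cells (Homo sapiens) for cytotoxicity, read by luminescence, with a stated time of 24 h (a lower number here means that less compound is tolerated, a higher number that more compound is tolerated), compound 3 is reported only as a limit, > 100000 nM. Compound 1 shares this position, at the limit of > 100000 nM in this assay, at which 2 of the 3 values shown sit. Compound 2 is the only one of the three with a number, 39000 nM.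

Compound 4 `COc1ccc(Cn2c(C(=O)N3CCC(C(=O)NCCC(C)C)CC3)cc3sccc32)cc1` differs from compound 3 in the side chain on the amide nitrogen: isobutyl in place of 3-bromophenyl on a saturated chain carbon bound to an amide-type nitrogen. This is isobutyl in place of 3-bromophenyl on a saturated chain carbon bound to an amide-type nitrogen. Cut one bond further out, it reads (3-bromobenzyl)amino to isopentylamino.

Within the data shown here, one measured step bears on this place: an at least 2.5-fold higher number from compound 2 to compound 3 (0.40 log units; beyond the scatter). That step lies beyond the scatter, but it replaces ethoxy, whereas compound 4 keeps the amide and changes only the group on it. With so little to go on, no step beyond the scatter is expected in this assay, and a report at the limit is the likeliest outcome. The expected step is a number no higher from compound 3 to compound 4 (the limit leaves the size open). For compound 4 the estimated value is 100000 nM, with an expected range of 40000 nM to 250000 nM.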

Compound 4, half-maximal cytotoxic concentration: 30900 nM
For compound 4 the middle estimate is 3.2-fold (0.51 log units) above the measured one; measured number below the stated range.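

Among the compounds shown, this is the first change made on the group carried by the amide nitrogen with the amide itself kept, and in this assay it moves the number beyond the scatter (an at least 3.2-fold lower number from compound 3 to compound 4 (0.51 log units; beyond the scatter)). The amide alone therefore does not secure the higher number, since isopentylamino and ethoxy on a carbonyl carbon sit level here (a 1.3-fold lower number from compound 2 to compound 4 (0.10 log units; within the scatter)), and among these three compounds only the (3-bromobenzyl)amino group of compound 3 stands apart. The entry for compound 3 is a limit, so the first step has a lower bound on its size and no upper one: the limit of > 100000 nM in this assay, at which 2 of the 4 values shown sit.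

The compounds shown leave open whether the aromatic ring, the bromine or the shape of the chain separates compound 3 from compound 4, since the change from 3-bromobenzyl to isopentyl alters all of these at once. Also open, going by these compounds, is where an unsubstituted benzyl group, a 3-chlorobenzyl group or a longer chain ending in an amine would fall on this amide.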